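The compounds below may be only part of what the source reports. "The series", "measured", "known", "first", "only" and "open" are said of these compounds alone.

Measured in an ADME assay on MDBK cells (Bos taurus) for cytotoxicity, read by MTT assay, with a stated time of 96 h; on this read-out higher numbers stand for lower toxicity in this test and lower numbers for higher toxicity in this test:
- compound 1 `CCNC(=S)Nc1cccc(C(F)(F)F)c1`: > 100000 nM (a limit of the assay)
- compound 2 `FC(F)(F)c1cccc(NC(=S)Nc2cccc(Br)c2)c1`: 10000 nM
- compound 3 `C=C(C)CNC(=S)Nc1cccc(C(F)(F)F)c1`: > 100000 nM (a limit of the assay)

Compound 3 stands at > 100000 nM, which is a limit and not a number. That is the limit of > 100000 nM in this assay, at which 2 of the 3 values shown sit.

The next change leads to compound 4 `Fc1ccccc1NC(=S)Nc1cccc(C(F)(F)F)c1`: 2-fluorophenyl in place of 2-methylprop-2-en-1-yl on an amide-type nitrogen. In words, this is 2-fluorophenyl in place of 2-methylprop-2-en-1-yl on an amide-type nitrogen.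

Among the measured compounds shown here, two measured steps bear on it. With 3-bromophenyl in place of ethyl, the data show an at least 10-fold lower number from compound 1 to compound 2 (1.00 log units; beyond the scatter). With 2-methylprop-2-en-1-yl in place of 3-bromophenyl, they show an at least 10-fold higher number from compound 2 to compound 3 (1.00 log units; beyond the scatter). Both lie beyond the scatter, and each has a limit at one end. For the measured compounds named here, compound 2 is the only measured compound with an aromatic ring at this place, so the precedent is thin.

A move to a lower number in this assay is therefore expected, with the expected step being an at least 6.6-fold lower number from compound 3 to compound 4 (0.82 log units; beyond the scatter). The estimate for compound 4 is 15000 nM. The expected range runs from 5000 nM to 60000 nM.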

Compound 4, half-maximal cytotoxic concentration: > 100000 nM
Compound 4: no number, only a limit; the forecaster's own chance of this, stated with the estimate: 20%; at least 6.6-fold (0.82 log units) between middle value and limit.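

In this assay compound 4 gives > 100000 nM, which is a limit of the assay. An aromatic ring on the amide-type nitrogen is thus not enough for a low number in this test: 2-fluorophenyl in place of 3-bromophenyl gives an at least 10-fold higher number from compound 2 to compound 4 (1.00 log units; beyond the scatter), and compound 2 is now the only compound shown with a measured number. The steps from compound 1 and from compound 3 to compound 4 cannot be read, as both ends of each are limits: the limit of > 100000 nM in this assay, at which 3 of the 4 values shown sit.

Going by these compounds, compound 2 and compound 4 differ in both the halogen and its place on the ring, so which of the two matters stays open. Also open, on these data alone, is whether a plain phenyl group on this nitrogen would read like compound 2 or sit at the limit.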